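The source may report more compounds than this note shows. Statements on the series, on what has been measured and on what is new or still open speak of the compounds shown alone.

Compound 1 `CCCCCC(CCO)n1cnc2c(Cl)nc(F)nc21` carries a fluoro group on its core, and in a functional assay on SW480 cells (Homo sapiens) for antiproliferative activity, read by MTT assay, with a stated time of 48 h (on this read-out lower numbers stand for stronger inhibition and higher numbers for weaker inhibition), compound 1 gives 7440 nM. Compound 2 `CCCCCC(CCO)n1cnc2c(Cl)ncnc21` differs from compound 1 by hydrogen in place of fluoro on an aromatic carbon. In this assay compound 2 reaches only the limit of > 50000 nM. That step, an at least 6.7-fold higher number from compound 1 to compound 2 (0.82 log units; beyond the scatter), rests on (the limit of > 50000 nM in this assay, at which 1 of the 3 values shown sits). Compound 3 `CCCCCCCC(CCO)n1cnc2c(Cl)nc(F)nc21` differs from compound 1 by ethyl in place of hydrogen on a saturated chain carbon, six bonds along the chain from an aromatic nitrogen, and in this assay compound 3 gives 26100 nM, a step of a 3.5-fold higher number from compound 1 to compound 3 (0.55 log units; beyond the scatter).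

Compound 4 `CCCCCCCC(CCO)n1cnc2c(Cl)ncnc21`, not yet measured, differs from compound 3 by hydrogen in place of fluoro on an aromatic carbon, the same change that separates compound 1 from compound 2. Compound 3 already sits higher than compound 1 by a 3.5-fold higher number from compound 1 to compound 3 (0.55 log units; beyond the scatter), and the earlier loss of fluoro gave an at least 6.7-fold higher number from compound 1 to compound 2 (0.82 log units; beyond the scatter). Compound 4 is therefore expected to shift by about a 6.7-fold higher number from compound 3 to compound 4 (0.83 log units; beyond the scatter). Compound 4 is estimated at 175000 nM, between 50000 nM and 600000 nM, most probably reported only as a limit.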

Compound 4, half-maximal inhibitory concentration: 3630 nM
Beside the measured number, compound 4's estimate is 48-fold (1.68 log units) above it; measured number below the stated range.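

In this assay the change of fluoro to hydrogen gives a 7.2-fold lower number from compound 3 to compound 4 (0.86 log units; beyond the scatter), so the change does not carry over in direction from the core of compound 1 to the core of compound 3: the same change on two cores in this assay, an at least 6.7-fold higher number (0.82 log units; beyond the scatter) from compound 1 to compound 2 and a 7.2-fold lower number (0.86 log units; beyond the scatter) from compound 3 to compound 4, at least 48-fold (1.68 log units) apart, beyond the scatter of two such steps The ethyl change also reverses, giving an at least 13-fold lower number from compound 2 to compound 4 (1.13 log units; beyond the scatter), while it raised the number on the core of compound 1: the same change on two cores in this assay, a 3.5-fold higher number (0.55 log units; beyond the scatter) from compound 1 to compound 3 and an at least 13-fold lower number (1.13 log units; beyond the scatter) from compound 2 to compound 4, at least 48-fold (1.68 log units) apart, beyond the scatter of two such steps Compound 2 is recorded only as a limit, > 50000 nM, so the exact size of both gaps remains unknown, and these compounds show that the two changes depend on each other but not why: the limit of > 50000 nM in this assay, at which 1 of the 4 values shown sits.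

On these data alone, it remains open whether the reversal holds with a longer chain. As far as these compounds go, it is also open how an amine or a methoxy group in place of fluoro would behave.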